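Swapping a chloropyridyl ether for a fluoromethylpyridyl ether

The compounds below may be only part of what the source reports. "The series", "measured", "known", "first", "only" and "open" are said of these compounds alone.

Measured compounds:
compound 1, `Cc1ccc(Oc2ccc3nc(COc4cccc(C(=O)O)c4)n(C)c3n2)cc1F`, gives 5.2 ug/mL in a physicochemical assay for solubility, read by HPLC, measured as thermodynamic solubility, with a stated time of 4 h, at pH 6.8; on this read-out higher numbers stand for higher solubility and lower numbers for lower solubility;
compound 2, `Cn1c(COc2cccc(C(=O)O)c2)nc2ccc(Oc3ccc4c(c3)CCC4)nc21`, gives 4.3 ug/mL;
compound 3, `Cn1c(COc2cccc(C(=O)O)c2)nc2ccc(Oc3cccc(Cl)n3)cc21`, gives 7.7 ug/mL.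

Compound 3 carries the highest of the three numbers, yet neither compound 1 nor compound 2 is separated from it beyond the scatter. Compound 4, `Cc1cnc(Oc2ccc3nc(COc4cccc(C(=O)O)c4)n(C)c3c2)c(F)c1`, differs from compound 3 by 3-fluoro-5-methylpyridin-2-yl in place of 6-chloropyridin-2-yl on an oxygen on an aromatic ring. For the measured compounds named here, the only measured step, a 1.2-fold lower number from compound 1 to compound 2 (0.08 log units; within the scatter), also exchanged the group on that oxygen and stayed within the scatter, so no step beyond the scatter is expected here. Compound 4 is therefore estimated at 7 ug/mL, in a range of 3 ug/mL to 16 ug/mL. For compound 4 the expected step is a 1.1-fold lower number from compound 3 to compound 4 (0.04 log units; within the scatter).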

Compound 4, solubility: 9.2 ug/mL
Compound 4: the middle estimate sits 1.3-fold (0.12 log units) below what was measured, and the stated range covers the measured number.
By their numbers in this assay, from the lowest: compounds 2, 1, 3 and 4 (each within the scatter of the next, the first and the last beyond it).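

In this assay, placing 3-fluoro-5-methylpyridin-2-yl in place of 6-chloropyridin-2-yl on an oxygen on an aromatic ring gives a 1.2-fold higher number from compound 3 to compound 4 (0.08 log units; within the scatter) and so stays within the scatter. This shows that, on this core, chlorine can give way to fluorine and methyl on the ring without a step beyond the scatter, and it is the second exchange at that oxygen to stay within it. Nothing measured here explains the result. On these data alone, whether an amine or a carboxylic acid in the group on that oxygen would carry the number beyond the scatter stays open.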